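This account rests on a few compounds, and the source may have more. Where it says the series, first, only, none or still open, it means among the compounds named here.

Measured compounds: compound 1 `O=Cc1cn(-c2ccccc2)nc1-c1ccc(Cl)cc1` gives 15500 nM; compound 2 `c1ccc(-c2nn(-c3ccccc3)cc2-c2nc3ccccc3[nH]2)cc1` gives 1550 nM; compound 3 `Clc1ccc2[nH]c(-c3cn(-c4ccccc4)nc3-c3ccccc3)nc2c1` gives 3480 nM.

Compound 3 stands second highest of the three numbers in a functional assay on HeLa cells (Homo sapiens) for antiproliferative activity, read by MTT assay, with a stated time of 48 h; on this read-out lower numbers stand for stronger inhibition and higher numbers for weaker inhibition. Within the data shown here, its nearest neighbour is compound 2, the only step that is known here: a 2.2-fold higher number from compound 2 to compound 3 (0.35 log units; beyond the scatter). Compound 1 lies furthest away, with a higher number than compound 3, so it inhibits growth less strongly.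

Compound 4 `Cc1ccc2[nH]c(-c3cn(-c4ccccc4)nc3-c3ccccc3)nc2c1` differs from compound 3 in one place: methyl in place of chloro on an aromatic carbon. Among the measured compounds shown here, no measured step of this kind exists among the three compounds; the only known step, from compound 2 to compound 3, concerns chloro in place of hydrogen at the same place and was modest. Methyl in place of chloro keeps a single heavy atom at that position, so the change is expected to be small, and no direction beyond the scatter is predicted with confidence. The estimated step is a 1.2-fold lower number from compound 3 to compound 4 (0.06 log units; within the scatter). Compound 4 is therefore expected to give about 3000 nM, with a range from 1500 nM to 6500 nM.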

Compound 4, half-maximal inhibitory concentration: 6560 nM
Beside the measured number, compound 4's estimate is 2.2-fold (0.34 log units) below it; measured number above the stated range.
By their numbers in this assay, from the lowest: compound 2; then compounds 3 and 4 (each within the scatter of the next); then compound 1.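

In this assay methyl in place of chloro gives a 1.9-fold higher number from compound 3 to compound 4 (0.28 log units; within the scatter) and so the two groups cannot be told apart at this position, on the six-membered aromatic ring of carbon only. Measured against hydrogen, methyl gives a 4.2-fold higher number from compound 2 to compound 4 (0.63 log units; beyond the scatter) and chloro gives a 2.2-fold higher number from compound 2 to compound 3 (0.35 log units; beyond the scatter) so both steps run the same way, and among these three compounds neither group improves on the hydrogen of compound 2. Nothing measured here explains this result.

Going by these compounds, whether an amine or a carboxylic acid at this position would bring the number down to that of compound 2, or lower still, stays open. Also open, on these data alone, is whether a longer chain would raise the number further than methyl does.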